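The source may report more compounds than this note shows. Statements on the series, on what has been measured and on what is new or still open speak of the compounds shown alone.

In a functional assay on MIA PaCa-2 cells (Homo sapiens) for inhibition, read by MTT assay, with a stated time of 72 h (a higher number here means a weaker inhibitor of growth, a lower number a stronger inhibitor of growth), compound 1 `O=S(=O)(NCCCCCCNCc1ccc(Br)cc1)c1c(Cl)cccc1Cl` gives 14700 nM and compound 2 `O=S(=O)(NCCCCCCNCc1ccc(Br)cc1)c1ccc2ccsc2c1` gives 6000 nM. Compound 2 holds the lowest of the two numbers, with a 2.5-fold lower number from compound 1 to compound 2 (0.39 log units; beyond the scatter) separating it from compound 1. Compound 3 `Cc1ccc(S(=O)(=O)NCCCCCCNCc2ccc(Br)cc2)cc1` carries 4-methylphenyl in place of 1-benzothiophen-6-yl on a sulfonyl sulfur. Going by the values given here, only the one measured step, the aryl exchange on the sulfonyl sulfur from compound 1 to compound 2, bears on this change, and it was modest. A similar step in this assay is expected, most likely back toward a higher number, so compound 3 is estimated at 10000 nM, between 4000 nM and 25000 nM, a step of a 1.7-fold higher number from compound 2 to compound 3 (0.22 log units; within the scatter).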

Compound 3, concentration for 50% growth inhibition: 12300 nM
The estimate for compound 3 lay 1.2-fold (0.09 log units) below the measured number; the range from low to high includes it.
By their numbers in this assay, from the lowest: compound 2; then compounds 3 and 1 (each within the scatter of the next).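

In this assay, 4-methylphenyl on the sulfonyl sulfur gives a 2.1-fold higher number from compound 2 to compound 3 (0.31 log units; beyond the scatter) as the change from 1-benzothiophen-6-yl, so this group now stands apart from two other aryl groups at this position. With a 1.2-fold lower number from compound 1 to compound 3 (0.08 log units; within the scatter) as the change from 2,6-dichlorophenyl, the 4-methylphenyl and 2,6-dichlorophenyl groups cannot be told apart here. No evidence on hand accounts for these differences.

Still open, from the compounds shown here alone, is whether a naphthyl or a pyridyl group on the sulfonyl sulfur would read like 1-benzothiophen-6-yl. Going by these compounds, the effect of a shorter chain on these aryl groups also remains open.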